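Swapping a Hydroxylated Side Chain for a Formyl Alkene

The source may hold more compounds than are shown below. What is called first, only, known or untested is meant among the compounds shown, and "the series" means these compounds.

Compound 2 `C=C[C@@](C)(O)CC[C@H]1C(=C)CC[C@@H]2[C@]1(C)CCC[C@]2(C)C(=O)O` reaches only a limit in a functional assay on A549 cells (Homo sapiens) for cytotoxicity, read by MTT assay, with a stated time of 48 h (a higher number here means a weaker inhibitor, a lower number a stronger inhibitor), where compound 2 gives > 40000 nM. Two other compounds were measured on a different core: compound 1 `C=CC(=C)CC[C@@H]1[C@@]2(C)CCC[C@](C)(COC(=O)/C=C/c3ccc(O)cc3)[C@@H]2CC[C@@]1(C)O` gives 20400 nM, and compound 3 `C=CC(=C)CC[C@@H]1[C@@]2(C)CCC[C@](C)(COC(=O)/C=C\c3ccc(O)c(OC)c3)[C@@H]2CC[C@@]1(C)O` gives 17300 nM. Going by the values given here, the only one-step comparison, a 1.2-fold lower number from compound 1 to compound 3 (0.07 log units; within the scatter), concerns 2-(4-hydroxy-3-methoxyphenyl)ethenyl in place of 2-(4-hydroxyphenyl)ethenyl on a carbonyl carbon, a different change from the one examined here. Compound 4 `C=C1CC[C@@H]2[C@](C)(CCC[C@]2(C)C(=O)O)[C@H]1C/C=C(\C)C=O` differs from compound 2 in a single place: 2-formylprop-1-en-1-yl in place of 2-hydroxy-2-methylbut-3-en-1-yl on a saturated chain carbon bound to a saturated ring carbon. Among the compounds with values here, no measured step bears on this change, and because compound 2 sits at the limit of > 40000 nM in this assay, at which 1 of the 3 values shown sits, there is no numerical anchor. Compound 4 is therefore expected to give about 40000 nM, in a wide range from 15000 nM to 100000 nM. The expected step of a number no higher from compound 2 to compound 4 (the limit leaves the size open) is essentially none beyond the scatter.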

Compound 4, half-maximal inhibitory concentration: > 40000 nM
Compound 4 ended at the assay's limit; the forecaster's own chance of this, stated with the estimate: 50%; the middle value lies on the limit itself.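

Compound 2 and compound 4 both stop at a limit of the assay, so no step can be read between them: the limit of > 40000 nM in this assay, at which 2 of the 4 values shown sit.

The compounds shown leave open whether 2-formylprop-1-en-1-yl in place of 2-hydroxy-2-methylbut-3-en-1-yl changes cytotoxicity at all.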